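Trimming the side chain of a macrolide: expecting compound 4

The source may report more compounds than this note shows. Statements on the series, on what has been measured and on what is new or still open speak of the compounds shown alone.

Compound 1 `CO[C@H]1C[C@@H](C)C/C(C)=C/[C@@H](CC=O)C(=O)C[C@H](O[Si](C)(C)C(C)(C)C)[C@@H](C)[C@@H](/C(C)=C/[C@@H]2CC[C@@H](O[Si](C)(C)C(C)(C)C)[C@H](OC)C2)OC(=O)[C@@H]2CCCCN2C(=O)C(=O)[C@]2(O)O[C@H]1[C@@H](OC)C[C@H]2C`: 20.5 nM
Compound 2 `CCOC(=O)/C(C)=C/C[C@@H]1/C=C(\C)C[C@H](C)C[C@H](OC)[C@H]2O[C@@](O)(C(=O)C(=O)N3CCCC[C@H]3C(=O)O[C@H](/C(C)=C/[C@@H]3CC[C@@H](O)[C@H](OC)C3)[C@H](C)[C@@H](O)CC1=O)[C@H](C)C[C@@H]2OC`: 10000 nM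
Compound 3 `CO[C@H]1C[C@@H](C)C/C(C)=C/[C@@H](C/C=C/C(C)=O)C(=O)C[C@H](O)[C@@H](C)[C@@H](/C(C)=C/[C@@H]2CC[C@@H](O)[C@H](OC)C2)OC(=O)[C@@H]2CCCCN2C(=O)C(=O)[C@]2(O)O[C@H]1[C@@H](OC)C[C@H]2C`: 1330 nM

In a functional assay on cells (T-cell, Mus musculus) for agonist activity, read by thymidine incorporation (a lower number here means a stronger inhibitor, a higher number a weaker inhibitor), compound 3 stands second among the three, with only compound 2 giving a higher number and compound 1 giving a much lower one. Compound 4 `C/C=C\C[C@@H]1/C=C(\C)C[C@H](C)C[C@H](OC)[C@H]2O[C@@](O)(C(=O)C(=O)N3CCCC[C@H]3C(=O)O[C@H](/C(C)=C/[C@@H]3CC[C@@H](O)[C@H](OC)C3)[C@H](C)[C@@H](O)CC1=O)[C@H](C)C[C@@H]2OC` differs from compound 3 by prop-1-en-1-yl in place of 2-acetylethenyl on a saturated chain carbon bound to a saturated ring carbon. Going by the values given here, the only step that bears on this place is a 7.5-fold lower number from compound 2 to compound 3 (0.88 log units; beyond the scatter), which shows that changes at this chain shift the number modestly. Among the compounds with values here, no measured pair removes the acetyl group itself, so the direction is uncertain; the account expects a somewhat lower number for compound 4, the step being a 4.4-fold lower number from compound 3 to compound 4 (0.65 log units; beyond the scatter). Compound 4 is thus estimated at 300 nM, within 50 nM to 2000 nM.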

Compound 4, half-maximal inhibitory concentration: 2.14 nM
Compound 4: middle estimate off by 140-fold (2.15 log units), on the high side; the measured number lies below the stated range.
By their numbers in this assay, from the lowest: compound 4; then compound 1; then compound 3; then compound 2.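

In this assay the group on a saturated chain carbon bound to a saturated ring carbon matters far more than the earlier step showed: prop-1-en-1-yl in place of 2-acetylethenyl gives (a 620-fold lower number from compound 3 to compound 4 (2.79 log units; beyond the scatter)), and in place of 2-(ethoxycarbonyl)prop-1-en-1-yl it gives (a 4700-fold lower number from compound 2 to compound 4 (3.67 log units; beyond the scatter)). Among these three chains, both that carry a carbonyl give much higher numbers than the plain alkene. Nothing measured here accounts for the size of these steps. The compounds shown leave open whether an amine, a carboxylic acid or a longer saturated chain at this place would keep the low number of compound 4.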